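A few compounds are considered here, and "the series" means these few. Any claim that something is new, unique, unknown or untested is made for them only; others in the source may bear on it.

Measured compounds in this study:
compound 1, `CCOC(=O)c1cc([Te]c2ccccc2)c2cc(OC)ccc2n1` — 128000 nM
compound 2, `CCOC(=O)c1cc([Se]c2ccccc2)c2ccccc2n1` — 86300 nM
compound 3, `CCOC(=O)c1cc([Se]c2ccc(OC)cc2)c2cc(OC)ccc2n1` — >= 54300 nM

All three share one core and were tested in a functional assay on SK-MEL-147 cells (Homo sapiens) for cytotoxicity, read by MTT assay, with a stated time of 24 h; on this read-out lower numbers stand for an effect already at smaller amounts and higher numbers for an effect only at larger amounts of compound. Compound 1 has the highest of the two numbers reported, with compound 2 as its nearest neighbour at a value that lies within the scatter of the method, so the two cannot be told apart. Among the measured compounds shown here, for compound 3 this assay reports only a limit and no number, >= 54300 nM; it is the single value sitting at the limit of >= 54300 nM in this assay, at which 1 of the 3 values shown sits.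

The unmeasured compound 4, `CCOC(=O)c1cc(C#CCCO)c2cc(OC)ccc2n1`, differs from compound 1 in one place: a group of 5 heavy atoms (4 carbon, 1 oxygen; no ring) in place of a group of 7 heavy atoms (6 carbon, 1 tellurium; one six-membered aromatic ring of carbon only), on an aromatic carbon. For the measured compounds named here, no pair among the measured compounds differs in just one place, so no measured step is available to guide the size of this change. Going by these compounds, the numbers for compound 1 and compound 2 show that swapping the chalcogen partner left the read-out within the scatter, but the present change is of a different kind and its effect is unknown.

The step of a 1.1-fold higher number from compound 1 to compound 4 (0.04 log units; within the scatter) is expected to stay within the scatter, in either direction. Compound 4 is therefore estimated to give 140000 nM, within a range from 45000 nM to 450000 nM.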

Compound 4, half-maximal effective concentration: > 150000 nM
Compound 4: only a limit was reported (the forecaster's own chance of this, stated with the estimate: 45%); middle value at least 1.0-fold (0.02 log units) away from the limit.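

In this assay compound 4 gives > 150000 nM, which is a limit of the assay and not a number. With 4-hydroxybut-1-yn-1-yl on the aromatic carbon opposite the ring nitrogen, in place of the tellurium-bearing group with its six-membered aromatic ring, the result is an at least 1.1-fold higher number from compound 1 to compound 4 (0.06 log units; that floor lies within the scatter). This is the first change at this position that can be read on its own, and it shows that a group with no tellurium and no ring here gives no sign of an effect at smaller amounts than compound 1, while how far the true number lies beyond the limit cannot be told: the limit of > 150000 nM in this assay, at which 1 of the 4 values shown sits.

The compounds shown leave open whether the triple bond, the chain length or the terminal hydroxyl of 4-hydroxybut-1-yn-1-yl has any bearing on the read-out, since these parts enter together in compound 4. They also leave open how a primary amine or a carboxylic acid at the end of this chain, or a longer chain at the same position, would read out on the shared core.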